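This account rests on a few compounds, and the source may have more. Where it says the series, first, only, none or still open, it means among the compounds named here.

Compound 3 `COc1ccc(NC(=O)C(=O)c2cn(C(C)C)c3ccccc23)cn1` has the lowest number of the three in a functional assay on FaDu cells (Homo sapiens) for cytotoxicity, read by MTT assay, with a stated time of 72 h; on this read-out lower numbers stand for higher toxicity in this test and higher numbers for lower toxicity in this test: compound 3 gives 85 nM, while compound 1 `COc1nsc(NC(=O)C(=O)c2cn(C(C)C)c3ccccc23)n1` gives 10400 nM and compound 2 `COc1ccc(NC(=O)C(=O)c2cn(C(C)C)c3c(Cl)cccc23)cn1` gives 10200 nM. Compound 4 `COc1nc(NC(=O)C(=O)c2cn(C(C)C)c3ccccc23)ns1` is not yet measured; it differs from compound 3 by a group of 7 heavy atoms (3 carbon, 2 nitrogen, 1 oxygen, 1 sulfur; one five-membered aromatic ring with 3 hetero atoms) in place of a group of 8 heavy atoms (6 carbon, 1 nitrogen, 1 oxygen; one six-membered aromatic ring with 1 hetero atom), on an amide-type nitrogen. The measured step that bears on this is a 120-fold lower number from compound 1 to compound 3 (2.09 log units; beyond the scatter), where a group closely related to the one entering here, the 3-methoxy-1,2,4-thiadiazol-5-yl, gave way to 6-methoxypyridin-3-yl; the step of a 120-fold lower number from compound 2 to compound 3 (2.08 log units; beyond the scatter) concerns a chloro elsewhere and does not apply. Running the relevant step backwards, compound 4 is expected to show a large rise, about a 94-fold higher number from compound 3 to compound 4 (1.97 log units; beyond the scatter), in this assay. The estimated value for compound 4 is 8000 nM, expected to lie between 2000 nM and 30000 nM.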

Compound 4, concentration lethal to 50% of the cells: > 10000 nM
Compound 4: only a limit was reported; the forecaster's own chance of this, stated with the estimate: 15%; at least 1.2-fold (0.09 log units) between middle value and limit.
By their numbers in this assay, from the lowest: compound 3; then compounds 2 and 1 (each within the scatter of the next).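

Replacing 6-methoxypyridin-3-yl on the amide-type nitrogen with a second five-membered aromatic ring with 3 hetero atoms also costs toxicity in this assay, with an at least 110-fold higher number from compound 3 to compound 4 (2.07 log units; beyond the scatter). Among these compounds, both five-membered rings, in compound 1 and compound 4, give far higher numbers than the six-membered ring of compound 3. Compound 4 has only a limit, so its step from compound 1 cannot be read: the limit of > 10000 nM in this assay, at which 1 of the 4 values shown sits.

Going by these compounds, whether the ring or its methoxy group matters more remains open. An unsubstituted pyridin-3-yl or a 4-methoxyphenyl group on that nitrogen would help separate the two.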